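Adding an Amino Group to Two Chloropurine Isomers

A few compounds are considered here, and "the series" means these few. Any claim that something is new, unique, unknown or untested is made for them only; others in the source may bear on it.

Compound 1, with the structure `ClCc1ccc(Cn2cnc3c(Cl)ncnc32)cc1`, and compound 2, with the structure `Nc1nc(Cl)c2ncn(Cc3ccc(CCl)cc3)c2n1`, differ in one place: compound 2 carries an amino group where compound 1 has a hydrogen. In a functional assay on MCF7 cells (Homo sapiens) for cytotoxicity, read by sulforhodamine B assay, with a stated time of 48 h (a lower number here means a stronger inhibitor of growth, a higher number a weaker inhibitor of growth), compound 1 gives 77600 nM, while compound 2 gives 17000 nM. The change from compound 1 to compound 2 is amino in place of hydrogen on an aromatic carbon and in this assay it brought a 4.6-fold lower number from compound 1 to compound 2 (0.66 log units; beyond the scatter).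

Compound 3, with the structure `ClCc1ccccc1Cn1cnc2c(Cl)ncnc21`, has the same atoms as compound 1 but joined differently; the difference between the two cores is not broken down here. In this assay compound 3 gives only a limit, > 100000 nM, so its true value is not known as a number; this is the limit of > 100000 nM in this assay, at which 1 of the 3 values shown sits.

Compound 4, with the structure `Nc1nc(Cl)c2ncn(Cc3ccccc3CCl)c2n1`, has not yet been measured. It relates to compound 3 exactly as compound 2 relates to compound 1, through (amino in place of hydrogen on an aromatic carbon), the same change made at the same kind of place. For compound 4 a step of an at least 1.6-fold lower number from compound 3 to compound 4 (0.22 log units; that floor lies within the scatter) is expected in this assay, resting on the modest gain seen as a 4.6-fold lower number from compound 1 to compound 2 (0.66 log units; beyond the scatter) and on the fact that compound 3 sits at the limit of > 100000 nM. Because compound 3 only reached that limit, the starting point is uncertain, and compound 4 is estimated to land near 60000 nM, somewhere between 20000 nM and 200000 nM, with a real chance that it too reports only a limit.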

Compound 4, concentration for total growth inhibition: 24600 nM
Compound 4: middle estimate off by 2.4-fold (0.39 log units), on the high side; low and high end bracket the measured number.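

In this assay, amino in place of hydrogen on an aromatic carbon again goes with a lower number on the second core, with an at least 4.0-fold lower number from compound 3 to compound 4 (0.60 log units; beyond the scatter), so the direction of the change seen on the first core carries over to this one. Compound 3 gives only a limit, > 100000 nM, and not a number, so the result shows a floor for the size of the step and not the size itself. Two cores are too few to show a general rule, and the steps on these two cores cannot be said to match or to differ in size: the same change on two cores in this assay, a 4.6-fold lower number (0.66 log units; beyond the scatter) from compound 1 to compound 2 and an at least 4.0-fold lower number (0.60 log units; beyond the scatter) from compound 3 to compound 4; the limit leaves it open whether they differ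

Only two cores are shown, each with this one change, so it stays open whether a third core would respond in the same direction and by a similar amount. Going by these compounds, it also stays open whether another group on the same aromatic carbon, such as a methylamino group or a hydroxyl group, would lower the number as amino does, or whether the lower numbers seen with amino would also appear in another cell line.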